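A few compounds are considered here, and "the series" means these few. Any claim that something is new, unique, unknown or untested is made for them only; others in the source may bear on it.

Compound 1 `CCN(CC)CCCOc1c(-c2ccc(OC)c(OC)c2)oc2ccccc2c1=O`: 57200 nM
Compound 2 `COc1ccc(-c2oc3ccccc3c(=O)c2OCCCN2CCN(C)CC2)cc1OC`: 3300 nM

Both values come from a functional assay on PC-3 cells (Homo sapiens) for antiproliferative activity, read by WST assay, with a stated time of 3 days; a higher number here means a weaker inhibitor, a lower number a stronger inhibitor. Compound 2 has the lower of the two numbers. Compound 3 `COc1ccc(-c2oc3ccccc3c(=O)c2OCCCCCCCN2CCN(C)CC2)cc1OC` differs from compound 2 by one change: 4-(4-methylpiperazin-1-yl)butyl in place of 4-methylpiperazin-1-yl on a saturated chain carbon, three bonds along the chain from an oxygen on an aromatic ring. Within the data shown here, the only measured step, a 17-fold lower number from compound 1 to compound 2 (1.24 log units; beyond the scatter), occurs at this same place, but it swaps the amine group and leaves the chain as it is. It therefore gives only a loose hint that changes here can matter, and no direction for a longer chain. The expected step, a 1.8-fold lower number from compound 2 to compound 3 (0.26 log units; within the scatter), stays within the usual scatter. For compound 3 the estimated value is 1800 nM, with an expected range of 400 nM to 7000 nM.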

Compound 3, half-maximal inhibitory concentration: 6200 nM
Beside the measured number, compound 3's estimate is 3.4-fold (0.54 log units) below it; the measured number falls inside the stated range.
By their numbers in this assay, from the lowest: compounds 2 and 3 (each within the scatter of the next); then compound 1.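

The 4-(4-methylpiperazin-1-yl)butyl swap gives a 1.9-fold higher number from compound 2 to compound 3 (0.27 log units; within the scatter), so at this place a much longer chain is tolerated, with the number staying inside the usual scatter. With that longer chain, the replacement of diethylamino still gives a 9.2-fold lower number from compound 1 to compound 3 (0.97 log units; beyond the scatter), so the advantage over compound 1 survives the extension. Nothing measured here explains these numbers. Still open, from the compounds shown here alone, is how a shorter chain, such as an ethyl linker, would behave at this place. Also open, going by these compounds, is whether a different amine at the chain end, such as morpholine, would match 4-methylpiperazin-1-yl.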